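Alkylthio chain series: shortening the branch

The source may report more compounds than this note shows. Statements on the series, on what has been measured and on what is new or still open speak of the compounds shown alone.

Compound 3 `COC(=O)[C@H]1N=C(SC(C)C)[C@H]2C(=O)N(c3ccccc3)C(=O)[C@H]21` gives 72% in a functional assay for inhibition, tested at 100 uM (a lower number here means less inhibition, a higher number more inhibition at the concentration tested (going by the name of the read-out)), the lowest of the three numbers; compound 2 `CCCSC1=N[C@H](C(=O)OC)[C@@H]2C(=O)N(c3ccccc3)C(=O)[C@H]12` gives 86% and compound 1 `CCSC1=N[C@@H](C(=O)OC)[C@@H]2C(=O)N(c3ccccc3)C(=O)[C@H]12` gives 91%, both beyond the scatter above compound 3. For the measured compounds named here, the only single-change step measured is a number 14 percentage points lower from compound 2 to compound 3 (beyond the scatter). Compound 4 `CCSC1=N[C@H](C(=O)OC)[C@@H]2C(=O)N(c3ccccc3)C(=O)[C@H]12` differs from compound 3 by hydrogen in place of methyl on a saturated chain carbon bound to a saturated chain carbon and a sulfur. That step undoes the branching, so a gain of about the size seen from compound 2 to compound 3 is expected, back into the range of compounds 1 and 2, which share the same sulfur substituent pattern as compound 4 without a branch. In this assay compound 4 is therefore expected near 86%, range 76% to 94%, an estimated step of a number 14 percentage points higher from compound 3 to compound 4 (beyond the scatter).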

Compound 4, a percentage reported as inhibition, at one concentration (the size of the read-out at that concentration, not a potency): 89%
Compound 4: the middle estimate sits 3 percentage points below what was measured; low and high end bracket the measured number.
By their numbers in this assay, from the lowest: compound 3; then compounds 2, 4 and 1 (each within the scatter of the next).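

In this assay, going from isopropylsulfanyl to ethylsulfanyl gives a number 17 percentage points higher from compound 3 to compound 4 (beyond the scatter), so among these compounds the lower number goes with the branched group on sulfur, not with the unbranched ethyl or propyl groups. Chain length between these two unbranched groups does not separate the compounds, with a number 3 percentage points higher from compound 2 to compound 4 (within the scatter). Configuration at the saturated ring carbon does not separate them either, with a number 2 percentage points lower from compound 1 to compound 4 (within the scatter), and the comparison is clean: the fact that compounds 1 and 4 differ only in the configuration as drawn

As far as these compounds go, whether a butyl chain, a benzyl group or a cyclopropyl group on sulfur would keep the number in this range remains open. Also open, from the compounds shown here alone, is what a carboxylic acid in place of the methyl ester would do.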